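This account rests on a few compounds, and the source may have more. Where it says the series, first, only, none or still open, it means among the compounds named here.

Measured so far in an assay on HEK293 cells for positive allosteric modulation of metabotropic glutamate receptor 2 (Rattus norvegicus), read by thallium flux, with a stated time of 2.5 min; a lower number here means that less compound is needed, a higher number that more compound is needed for the effect:
compound 1, `Cc1c(OCCCCOCOc2ccc(C(=O)O)cc2)ccc(C(=O)CC2CCCC2)c1O`, gives 228 nM
compound 2, `Cc1c(OCCCCOc2cccc(C(=O)O)c2)ccc(C(=O)CC2CCCC2)c1O`, gives 451 nM
compound 3, `COc1ccc(C(=O)O)cc1OCCCCOc1ccc(C(=O)CC2CCCC2)c(O)c1C`, gives 425 nM

Compound 2 sits among these three with no separation that the assay can resolve: the step of a 2.0-fold higher number from compound 1 to compound 2 (0.30 log units; within the scatter) and the step of a 1.1-fold lower number from compound 2 to compound 3 (0.03 log units; within the scatter) both fall within the scatter, as does a 1.9-fold higher number from compound 1 to compound 3 (0.27 log units; within the scatter). The three numbers are, for working purposes, one value.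

Compound 4, `Cc1c(OCCCCOc2cccc(C(=O)O)c2)ccc(C(=O)CC(C)C)c1O`, is the next point. It differs from compound 2 in one place: isopropyl in place of cyclopentyl on a saturated chain carbon bound to a carbonyl carbon.

Within the data shown here, none of the measured steps touches this end of the molecule. The steps from compound 1 to compound 2 and from compound 2 to compound 3 vary only the aryl acid attached through the four-carbon linker, and the part bound to the carbonyl is held constant in all three. Among the measured compounds shown here, there is therefore no measured step on which to rest a prediction of direction, and the only guide is that every change tried so far in this assay has stayed within the scatter.

The expectation for compound 4 is accordingly a step of a 1.3-fold higher number from compound 2 to compound 4 (0.12 log units; within the scatter), that is, no change beyond the scatter, with a wide range to reflect the absence of any comparable step. Compound 4 is estimated at 600 nM, in the range 250 nM to 1600 nM.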

Compound 4, half-maximal effective concentration: 222 nM
The estimate for compound 4 lay 2.7-fold (0.43 log units) above the measured number; measured number below the stated range.
By their numbers in this assay, from the lowest: compounds 4, 1, 3 and 2 (each within the scatter of the next, the first and the last beyond it).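

Compounds 1, 2 and 3 all carry cyclopentyl on the saturated chain carbon bound to a carbonyl carbon, so they gave no reading of this place; in this assay, isopropyl in place of cyclopentyl gives a modest step beyond the scatter (a 2.0-fold lower number from compound 2 to compound 4 (0.31 log units; beyond the scatter)). The place therefore responds to the group it carries, which the changes to the aryl acid, all within the scatter, gave no means of telling, and the five-membered ring of cyclopentyl is not required for the effect in this pair, since the open-chain isopropyl gives the lower number. No measurement at hand bears on the reason for this step.

As far as these compounds go, this reading rests on one pair, with the 3-carboxyphenyl end of compound 2 held fixed, so whether isopropyl gives the same step with the acid ends of compound 1 or compound 3 remains open. Also open, from the compounds shown here alone, is how far the trend runs at this place: a methyl, a tert-butyl, a cyclohexyl or a phenyl there would show whether the number keeps following the size and shape of the group or whether isopropyl is a local optimum.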